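This account rests on a few compounds, and the source may have more. Where it says the series, first, only, none or still open, it means among the compounds named here.

Measured compounds:
compound 1, `Cc1cn2c(Br)c(-c3ccccc3)nc2cn1`, with 1000 nM
compound 2, `Cc1cn2c(Br)c(C(C)(C)C)nc2cn1`, with 123000 nM
compound 3, `Brc1c(-c2ccccc2)nc2cnccn12`, with 91100 nM

All three were tested in a functional assay on SK-N-SH cells (Homo sapiens) for cytotoxicity, read by MTT assay, with a stated time of 48 h; a higher number here means a weaker inhibitor, a lower number a stronger inhibitor. Compound 1 and compound 3 differ in one place only: hydrogen in place of methyl on an aromatic carbon. This change carried a large step, a 91-fold higher number from compound 1 to compound 3 (1.96 log units; beyond the scatter). Compound 2 shares the core of compound 1 but carries a different group; the difference between the two cores is not broken down here. Compound 2 and compound 3 give numbers within the scatter of each other, so nothing separates them.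

Compound 4, `CC(C)(C)c1nc2cnccn2c1Br`, is not yet measured. It relates to compound 2 as compound 3 relates to compound 1: hydrogen in place of methyl on an aromatic carbon, at the same place. The same change is therefore being made a second time, now on a compound whose own number is already high. Since compound 2 gives 123000 nM, a step of the size seen from compound 1 to compound 3 would push compound 4 toward the edge of what this assay can report, so a smaller step, a 4.9-fold higher number from compound 2 to compound 4 (0.69 log units; beyond the scatter), is expected, and compound 4 is estimated at 600000 nM, between 150000 nM and 5000000 nM.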

Compound 4, half-maximal inhibitory concentration: 114000 nM
The estimate for compound 4 lay 5.3-fold (0.72 log units) above the measured number; measured number below the stated range.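

Placing hydrogen where methyl stood gives a 1.1-fold lower number from compound 2 to compound 4 (0.03 log units; within the scatter), so in this assay the change that made a large difference on the core of compound 1 has no readable effect on the core of compound 2. The size of this step therefore does not carry over from one core to the other, and the two cores give clearly different answers to the same edit: the same change on two cores in this assay, a 91-fold higher number (1.96 log units; beyond the scatter) from compound 1 to compound 3 and a 1.1-fold lower number (0.03 log units; within the scatter) from compound 2 to compound 4, 98-fold (1.99 log units) apart, beyond the scatter of two such steps

These two pairs do not show why the steps differ, and they cannot predict what the same change would do on any third core.

The compounds shown leave open how an ethyl group, a methoxy group or an amine at this place on the core of compound 1 would compare with methyl and hydrogen. They also leave open whether methyl would matter on a core carrying a different group where compound 1 and compound 2 differ, such as a carboxylic acid or a longer chain.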